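Chloro to methyl on the aryl-piperazine: working notes

This account rests on a few compounds, and the source may have more. Where it says the series, first, only, none or still open, it means among the compounds named here.

Measured so far in an assay on HEK293 cells for inhibition of Voltage-dependent T-type calcium channel subunit alpha-1G (Homo sapiens), read by patch clamp; a higher number here means a weaker inhibitor, a lower number a stronger inhibitor:
- compound 1 `CCCc1nc(-c2ccccc2)c(CNCCCN2CCN(c3ccccc3Cl)CC2)o1` gives 2800 nM
- compound 2 `CCCc1nc(-c2ccccc2)c(CNCCN2CCN(c3ccc(OC)cc3)CC2)o1` gives 9200 nM
- compound 3 `CCCc1nc(-c2ccccc2)c(CNCCN2CCN(c3ccccc3)CC2)o1` gives 10300 nM

Compound 1 stands lowest of the three, with compound 2 nearest and compound 3 furthest, both beyond the scatter. Compound 4 `CCCc1nc(-c2ccccc2)c(CNCCCN2CCN(c3ccccc3C)CC2)o1` differs from compound 1 by methyl in place of chloro on an aromatic carbon. Among the measured compounds shown here, no measured step touches this position directly; the only step, a 1.1-fold higher number from compound 2 to compound 3 (0.05 log units; within the scatter), concerns a substituent on the same kind of aromatic ring and stayed within the scatter. A modest step is therefore expected in this assay, if any, with no clear direction. Compound 4 is estimated at 3500 nM, range 1400 nM to 9000 nM. This estimate means a 1.3-fold higher number from compound 1 to compound 4 (0.10 log units; within the scatter).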

Compound 4, half-maximal inhibitory concentration: 8750 nM
Estimate against measurement, compound 4: 2.5-fold (0.40 log units) below; the range from low to high includes it.
By their numbers in this assay, from the lowest: compound 1; then compounds 4, 2 and 3 (each within the scatter of the next).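

In this assay, the change from 2-chlorophenyl to 2-methylphenyl gives a step beyond the scatter: a 3.1-fold higher number from compound 1 to compound 4 (0.49 log units; beyond the scatter). Among the compounds shown here, this position therefore responds to an exchange of one heavy atom for another, with no change in the counted donors, acceptors or charge, whereas the only earlier step, hydrogen in place of methoxy, stayed within the scatter: a 1.1-fold higher number from compound 2 to compound 3 (0.05 log units; within the scatter). Nothing shown here accounts for the difference between chloro and methyl.

Still open, as far as these compounds go, is where fluoro, bromo or an amine on this carbon would fall relative to compound 1 and compound 4. Also open, from the compounds shown here alone, is whether the step holds with a longer chain in the linker.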